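Replacing a furan ring on a thiophene-based aminoketone

A few compounds are considered here, and "the series" means these few. Any claim that something is new, unique, unknown or untested is made for them only; others in the source may bear on it.

Measured compounds:
compound 1 `CC(C)(C)Cc1c(-c2ccoc2)sc(N)c1C(=O)c1ccc(Cl)cc1` — 1%
compound 2 `CC(C)(C)Cc1c(-c2ccccc2)sc(N)c1C(=O)c1cccc(Cl)c1` — 5%

Compound 1 `CC(C)(C)Cc1c(-c2ccoc2)sc(N)c1C(=O)c1ccc(Cl)cc1` and compound 2 `CC(C)(C)Cc1c(-c2ccccc2)sc(N)c1C(=O)c1cccc(Cl)c1` share a core carrying an amino group, a neopentyl group and a chlorinated benzoyl group. In an assay on CHO cells for displacement of a labelled ligand from adenosine receptor A3 (Homo sapiens), read by scintillation counting, tested at 10 uM (on this read-out higher numbers stand for more inhibition at the one concentration tested (going by the name of the read-out) and lower numbers for less inhibition), compound 1 gives 1%, and in this assay compound 2 gives 5%. The two numbers lie within the scatter of each other, so compound 1 cannot be set apart from compound 2 on this read-out; both show almost no inhibition at the concentration tested.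

Compound 3 `COc1ccc(-c2sc(N)c(C(=O)c3ccc(Cl)cc3)c2CC(C)(C)C)cc1` has not yet been tested in this assay. Its structure differs from compound 1 in one place: 4-methoxyphenyl in place of furan-3-yl on an aromatic carbon. For the measured compounds named here, no step between measured compounds is available for this change. Compound 2, which carries a phenyl group at the same place, gives a number close to compound 1, so the step of a number 4 percentage points higher from compound 1 to compound 3 (within the scatter) is expected to stay within the scatter. Compound 3 is estimated to give 5%, with a range from -8% to 20%.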

Compound 3, a percentage reported as inhibition, at one concentration (the size of the read-out at that concentration, not a potency): 2%
Compound 3: the middle estimate sits 3 percentage points above what was measured; measured number inside the range.
By their numbers in this assay, from the lowest: compounds 1, 3 and 2 (each within the scatter of the next).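

In this assay, 4-methoxyphenyl in place of furan-3-yl on this aromatic carbon, next to the ring sulfur, amounts to a number 1 percentage points higher from compound 1 to compound 3 (within the scatter). On this core, then, a five-membered aromatic ring with 1 hetero atom and a six-membered aromatic ring of carbon only, bearing a methoxy group, cannot be told apart at the one concentration tested, and the change in heavy atoms brings no step beyond the scatter. Nothing at hand offers an explanation for this result.

From the compounds shown here alone, what an amine or a carboxylic acid would do on this same aromatic carbon stays open. Also open, going by these compounds, is whether replacing the neopentyl group with a shorter chain such as ethyl would give a number beyond the scatter of compound 1 in this assay.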